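The source may report more compounds than this note shows. Statements on the series, on what has been measured and on what is new or still open speak of the compounds shown alone.

In an ADME assay on HCT-116 cells (Homo sapiens) for cytotoxicity, read by CellTiter-Glo, with a stated time of 72 h (a lower number here means a stronger inhibitor, a higher number a weaker inhibitor), compound 1, whose structure is `CC1CCN(C2CCN(S(=O)(=O)c3ccc(Cl)nc3)CC2)CC1`, gives only a limit of the assay, > 10000 nM. Compound 2, `COc1ccc(-c2ccc(S(=O)(=O)N3CCC(N4CCC(C)CC4)CC3)cc2)cc1`, is the other compound measured here; in this assay compound 2 also gives only a limit, > 5000 nM. Compound 3, `CC1CCN(C2CCN(S(=O)(=O)c3ccc(Cl)cc3Cl)CC2)CC1`, has not been measured. It differs from compound 1 in one place: 2,4-dichlorophenyl in place of 6-chloropyridin-3-yl on a sulfonyl sulfur. For the measured compounds named here, no measured pair shows what such a change does, so the step is expected to lie within the scatter, in no particular direction. Compound 3 is therefore estimated at 15000 nM, between 5000 nM and 50000 nM, a step that the limit leaves unreadable from compound 1 to compound 3.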

Compound 3, half-maximal inhibitory concentration: > 5000 nM
Compound 3: no number, only a limit (the forecaster's own chance of this, stated with the estimate: 85%); the middle value is on the limit's open side.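

Compound 1 and compound 3 each give only a limit in this assay, and the step between them cannot be read. The compounds shown leave open whether 2,4-dichlorophenyl and 6-chloropyridin-3-yl differ at all here.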